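The compounds below may be only part of what the source reports. "The series", "measured", "known", "first", "only" and "open" are said of these compounds alone.

Measured in a physicochemical assay for solubility, measured as kinetic solubility; a higher number here means a more soluble compound, a lower number a less soluble compound:
- compound 1 `COc1cc(-c2noc([C@H](C)NC(=O)c3cc(C(F)(F)F)nn3C)n2)ccn1`: 156000 nM
- compound 2 `COc1cc(-c2noc([C@H](C)NC(=O)c3cc(C(F)(F)F)nn3C)n2)cc(C)n1`: 3000 nM

Compound 2 holds the lower of the two numbers, at 3000 nM, well under compound 1 at 156000 nM. Compound 3 `C[C@H](NC(=O)c1cc(C(F)(F)F)nn1C)c1nc(-c2ccnc(C3CC3)c2)no1` has 2-cyclopropylpyridin-4-yl in place of 2-methoxy-6-methylpyridin-4-yl on an aromatic carbon.

For the measured compounds named here, only one measured step bears on this change: a 52-fold lower number from compound 1 to compound 2 (1.72 log units; beyond the scatter), a large step for methyl in place of hydrogen on an aromatic carbon. Going by the values given here, compound 3 lacks that methyl, but no measured step covers cyclopropyl in place of methoxy, so only part of that step is expected to return. A moderately higher number is therefore expected in this assay. The expected change is a 4.0-fold higher number from compound 2 to compound 3 (0.60 log units; beyond the scatter). The estimate for compound 3 is 12000 nM, with an expected range of 2500 nM to 60000 nM.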

Compound 3, solubility: 16000 nM
Estimate against measurement, compound 3: 1.3-fold (0.12 log units) below, within the range that was stated.
By their numbers in this assay, from the lowest: compound 2; then compound 3; then compound 1.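

In this assay cyclopropyl in place of methoxy on an aromatic carbon now has a step of its own (a 9.8-fold lower number from compound 1 to compound 3 (0.99 log units; beyond the scatter)), so the number falls with this change even when no methyl is present. The full exchange of 2-methoxy-6-methylpyridin-4-yl for 2-cyclopropylpyridin-4-yl gives a rise (a 5.3-fold higher number from compound 2 to compound 3 (0.73 log units; beyond the scatter)), which places compound 3 between compound 2 and compound 1 and shows that this position tolerates more than one substituent change with a large spread of numbers. No supporting measurement accompanies these numbers, so no cause can be assigned to either group.

As far as these compounds go, whether methyl on 2-cyclopropylpyridin-4-yl would lower the number as far as it does on the methoxy-bearing ring stays open. Also open, from the compounds shown here alone, is how a dimethylamino group or a morpholine in place of cyclopropyl would read in this assay on this ring.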